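A few compounds are considered here, and "the series" means these few. Any claim that something is new, unique, unknown or untested is made for them only; others in the source may bear on it.

Measured so far:
- compound 1, `O=S1(=O)c2ccccc2CN1c1cc(F)cc(OCc2ccccc2)c1`: 2450 nM
- compound 2, `CCCCc1ccc(NS(=O)(=O)c2ccc(F)cc2)cc1`: 8130 nM

In a functional assay on Flp-In T-REx293 cells for antagonist activity at Free fatty acid receptor 1 (Homo sapiens), read by calcium flux (on this read-out lower numbers stand for stronger inhibition and higher numbers for weaker inhibition), compound 2 gives 8130 nM, the higher of the two numbers, with compound 1 lower by a gap beyond the scatter. Compound 3, `O=S(=O)(Nc1ccc(Oc2ccccc2)cc1)c1ccc(F)cc1`, has not been measured; it differs from compound 2 by phenoxy in place of butyl on an aromatic carbon. For the measured compounds named here, with no step between measured compounds available for this change, the expectation for this assay rests on the change alone: a modest move toward a lower number is expected, of size a 2.0-fold lower number from compound 2 to compound 3 (0.31 log units; beyond the scatter), though a result within the scatter would not surprise. Compound 3 is estimated at 4000 nM, expected between 1500 nM and 12000 nM.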

Compound 3, half-maximal inhibitory concentration: 12900 nM
Compound 3: middle estimate off by 3.2-fold (0.51 log units), on the low side; measured number above the stated range.
By their numbers in this assay, from the lowest: compound 1; then compounds 2 and 3 (each within the scatter of the next).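

In this assay, phenoxy in place of butyl on this aromatic carbon gives a 1.6-fold higher number from compound 2 to compound 3 (0.20 log units; within the scatter), so the two groups cannot be told apart at this position. Adding a six-membered aromatic ring and a hydrogen-bond acceptor here therefore brings no shift beyond the scatter. Nothing measured on these compounds bears on this result.

On these data alone, whether a carboxylic acid, an amine or a longer chain at this position would move the number beyond the scatter remains open. So does whether butyl and phenoxy would also match on the core of compound 1.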